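Swapping Chloro for Fluoro on the Core of Compound 3

The source may report more compounds than this note shows. Statements on the series, on what has been measured and on what is new or still open speak of the compounds shown alone.

The measured compounds:
- Compound 1 `O=c1oc2ccc(Cl)cc2c(=O)n1-c1ccc(I)cc1F` gives 6900 nM in an ADME assay on RAW264.7 cells (Mus musculus) for cytotoxicity, read by MTT assay, with a stated time of 24 h; on this read-out higher numbers stand for lower toxicity in this test and lower numbers for higher toxicity in this test.
- Compound 2 `O=c1oc2ccc(F)cc2c(=O)n1-c1ccc(F)cc1F` gives 19900 nM in this assay.
- Compound 3 `O=c1oc2ccc(Cl)cc2c(=O)n1-c1ccc(Br)cc1F` gives 8100 nM in this assay.

Compound 3 stands second highest of the three numbers. Among the compounds with values here, its nearest neighbour is compound 1, and the only measured single step, a 1.2-fold higher number from compound 1 to compound 3 (0.07 log units; within the scatter), lies within the scatter. Within the data shown here, the furthest number is that of compound 2, which is higher than the number of compound 3 by a margin beyond the scatter; compound 2 differs from compound 3 in two places at once, so no single step links them.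

Compound 4 `O=c1oc2ccc(F)cc2c(=O)n1-c1ccc(Br)cc1F` is the next compound. The change from compound 3 to compound 4 is fluoro in place of chloro on an aromatic carbon. Among the measured compounds shown here, no measured step isolates this change. For the measured compounds named here, the only hint is the pair compound 2 and compound 3: compound 2 carries fluoro where compound 3 carries chloro on the core, and also fluoro in place of bromo elsewhere, and compound 2 shows the higher number. The step from compound 3 to compound 4 is therefore expected to be a 1.6-fold higher number from compound 3 to compound 4 (0.21 log units; within the scatter), a rise partway toward the number of compound 2. Compound 4 is expected to give 13000 nM in this assay, estimated between 6500 nM and 26000 nM.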

Compound 4, half-maximal cytotoxic concentration: 7200 nM
Beside the measured number, compound 4's estimate is 1.8-fold (0.26 log units) above it; measured number inside the range.
By their numbers in this assay, from the lowest: compounds 1, 4 and 3 (each within the scatter of the next); then compound 2.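

Within the data shown here, with the bromo group held constant, the step of a 1.1-fold lower number from compound 3 to compound 4 (0.05 log units; within the scatter) gives the first direct reading of fluoro in place of chloro on this aromatic carbon of the core, and in this assay the two halogens cannot be told apart beyond the usual scatter of repeated measurements. The step of a 2.8-fold lower number from compound 2 to compound 4 (0.44 log units; beyond the scatter) isolates the other place of change, where compound 4 carries bromo and compound 2 carries fluoro, and although modest, it is the only measured single step so far that lies beyond the scatter; among these compounds, the higher number of compound 2 therefore goes with the fluoro it carries in place of bromo, not with the fluoro on the core. Nothing available here gives a reason for either step.

Going by these compounds, the core reading rests on a single matched pair carrying bromo, so it remains open whether fluoro and chloro would also match with iodo at the other place of change. On these data alone, it also remains open whether a group that is not a halogen, such as an amine or a methoxy group, on this aromatic carbon of the core would shift the number.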